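The compounds below may be only part of what the source reports. "The series", "measured", "known", "first", "only" and "open" are said of these compounds alone.

In an assay on HEK293 cells for displacement of a labelled ligand from Translocator protein (Homo sapiens), read by scintillation counting, with a stated time of 90 min (a lower number here means a stronger inhibitor, a higher number a weaker inhibitor), the measured compounds are: compound 1 `CC(=O)N(Cc1ccc(OCCF)cc1)c1cc(C)cc(C)c1` with 3930 nM; compound 2 `CCN(CC)C(=O)CN(Cc1ccccc1)c1cc(C)cc(C)c1` with 4260 nM; compound 3 `CCN(CC)C(=O)CN(Cc1ccc(OC)cc1)c1cc(C)cc(C)c1` with 4210 nM.

Compound 3 stands second highest of these three numbers, and all three lie within the scatter of one another. Within the data shown here, the only measured step, a 1.0-fold lower number from compound 2 to compound 3 (0.01 log units; within the scatter), is within the scatter. Compound 4 `CCN(CC)C(=O)CN(Cc1ccc(OCCF)cc1)c1cc(C)cc(C)c1` carries fluoromethyl in place of hydrogen on a saturated chain carbon bound to an oxygen on an aromatic ring. Among the measured compounds shown here, no measured step covers this change; compound 1, which carries the 2-fluoroethoxy group on a different core, shows a number close to compound 3. The step is therefore expected to be a 1.0-fold lower number from compound 3 to compound 4 (0.01 log units; within the scatter), with no change beyond the scatter. Compound 4 is estimated at 4100 nM, in the range 2000 nM to 8500 nM.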

Compound 4, inhibition constant: > 10000 nM
Compound 4: only a limit was reported (the forecaster's own chance of this, stated with the estimate: 5%); middle value at least 2.4-fold (0.38 log units) from the limit.
By their numbers in this assay, from the lowest: compounds 1, 3 and 2 (each within the scatter of the next). At a limit, above all of these: compound 4.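

In this assay compound 4 gives only a limit, > 10000 nM. Lengthening methoxy to 2-fluoroethoxy is not silent, giving an at least 2.3-fold higher number from compound 3 to compound 4 (0.37 log units; beyond the scatter), and measured against hydrogen the 2-fluoroethoxy group gives an at least 2.3-fold higher number from compound 2 to compound 4 (0.37 log units; beyond the scatter), whereas methoxy had given only a 1.0-fold lower number from compound 2 to compound 3 (0.01 log units; within the scatter). With 2-fluoroethoxy held, (diethylcarbamoyl)methyl in place of acetyl gives an at least 2.5-fold higher number from compound 1 to compound 4 (0.40 log units; beyond the scatter), so among these compounds the loss appears only where the two groups stand together. On these data alone, whether it follows the fluorine or the longer chain stays open, and a plain ethoxy or a 2-hydroxyethoxy group would separate the two. As far as these compounds go, how far compound 4 actually lies past its limit also stays open.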